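A few compounds are considered here, and "the series" means these few. Any claim that something is new, unique, unknown or untested is made for them only; others in the source may bear on it.

In a physicochemical assay for solubility, read by spectrophotometry, measured as kinetic solubility, at pH 8, tested at 500 uM (on this read-out lower numbers stand for lower solubility and higher numbers for higher solubility), three compounds with a shared core have been measured, and they differ in the group on the amide-type nitrogen. Compound 1 `Cn1cc(NC(=O)c2ccncc2Nc2cc(-c3ccc4ccn(C)c4c3)c3nccnc3c2)cn1` gives 2 ug/mL, compound 2 `Cn1ccc2ccc(-c3cc(Nc4cnccc4C(=O)NC4CCNC(=O)C4)cc4nccnc34)cc21` gives 242 ug/mL, and compound 3 `CN1CCC(NC(=O)c2ccncc2Nc2cc(-c3ccc4ccn(C)c4c3)c3nccnc3c2)CC1=O` gives 48 ug/mL, so compound 3 sits in the middle of the three.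

Within the data shown here, compound 4 `CC(=O)N1CC(NC(=O)c2ccncc2Nc2cc(-c3ccc4ccn(C)c4c3)c3nccnc3c2)C1` keeps the core and changes only that group: 1-acetylazetidin-3-yl in place of 1-methyl-2-oxopiperidin-4-yl on an amide-type nitrogen. A four-membered non-aromatic ring replaces a six-membered one, and neither group carries a net charge.

Among the measured compounds shown here, no measured step makes this exact swap, so the evidence is indirect. The large steps, a 120-fold higher number from compound 1 to compound 2 (2.08 log units; beyond the scatter) and a 24-fold higher number from compound 1 to compound 3 (1.38 log units; beyond the scatter), both replace 1-methyl-1H-pyrazol-4-yl, a change that compound 4 does not repeat relative to compound 3. The closest in scale is the modest 5.0-fold lower number from compound 2 to compound 3 (0.70 log units; beyond the scatter). A small step is therefore expected, probably none beyond the scatter, and the estimate is a 1.3-fold higher number from compound 3 to compound 4 (0.10 log units; within the scatter). For compound 4 the expected value is 60 ug/mL, with an estimated range from 20 ug/mL to 180 ug/mL.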

Compound 4, solubility: 244 ug/mL
For compound 4 the middle estimate is 4.1-fold (0.61 log units) below the measured one; measured number outside the range, above it.
By their numbers in this assay, from the lowest: compound 1; then compound 3; then compounds 2 and 4 (each within the scatter of the next).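

In this assay, a swap between two uncharged groups with the same counts of donors and acceptors can still move the number, as shown by a 5.1-fold higher number from compound 3 to compound 4 (0.71 log units; beyond the scatter) and the replacement of 1-methyl-2-oxopiperidin-4-yl with 1-acetylazetidin-3-yl. Yet 1-acetylazetidin-3-yl cannot be told apart from 2-oxopiperidin-4-yl, given a 1.0-fold higher number from compound 2 to compound 4 (0.00 log units; within the scatter), and it matches the large gain over 1-methyl-1H-pyrazol-4-yl seen in a 120-fold higher number from compound 1 to compound 4 (2.09 log units; beyond the scatter). Nothing measured here explains these steps.

The step to compound 4 changes ring size and swaps the ring carbonyl for an acetyl together, so 1-acetylpiperidin-4-yl would be needed to separate those two changes. As far as these compounds go, how a ring carrying a plain amine or a carboxylic acid would behave on this amide-type nitrogen also remains open.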